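A few compounds are considered here, and "the series" means these few. Any claim that something is new, unique, unknown or untested is made for them only; others in the source may bear on it.

Compound 1 `Cc1ccc(S(=O)(=O)NC(=O)/C=C/c2ccccc2)cc1` is an N-acylsulfonamide built from a cinnamoyl unit and a tolylsulfonyl unit. Within the data shown here, in a functional assay on B16-F10 cells (Mus musculus) for antiproliferative activity, read by ELISA and MTT assay, with a stated time of 48 h (on this read-out higher numbers stand for weaker inhibition and lower numbers for stronger inhibition), compound 1 gives 13.8 ug/mL, the higher of the two numbers measured so far. Among the measured compounds shown here, its only measured relative is compound 2 `O=C(/C=C/c1ccccc1)NS(=O)(=O)c1ccc(Br)cc1`, which in this assay gives 3.9 ug/mL; the change a 3.5-fold lower number from compound 1 to compound 2 (0.55 log units; beyond the scatter) is the single step available, and it sits on the sulfonyl-bearing ring.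

Compound 3 `Cc1ccc(S(=O)(=O)NC(=O)/C=C/c2ccc(F)cc2)cc1` departs from compound 1 in a different place: fluoro in place of hydrogen on an aromatic carbon, which read one bond further out is phenyl to 4-fluorophenyl on the cinnamoyl side. For the measured compounds named here, no measured pair touches this ring, so the step from compound 1 to compound 2 gives no direct guide; it shows only that a change on the other aromatic ring moved the number modestly. With nothing to point either way, a step within the scatter is expected, and compound 3 is estimated at 10 ug/mL (range 4 ug/mL to 25 ug/mL), which corresponds to an expected 1.4-fold lower number from compound 1 to compound 3 (0.14 log units; within the scatter) relative to compound 1.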

Compound 3, half-maximal inhibitory concentration: 4.8 ug/mL
Estimate against measurement, compound 3: 2.1-fold (0.32 log units) above; the range from low to high includes it.
By their numbers in this assay, from the lowest: compounds 2 and 3 (each within the scatter of the next); then compound 1.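

In this assay the phenyl ring of the cinnamoyl side proves responsive: fluoro in place of hydrogen, para to a large group, gives a 2.9-fold lower number from compound 1 to compound 3 (0.46 log units; beyond the scatter), a modest step but one beyond the scatter. Among these compounds, until now, the only step available was a 3.5-fold lower number from compound 1 to compound 2 (0.55 log units; beyond the scatter), on the sulfonyl-bearing ring; the core of compound 1 now shows a change in its number from a single substitution on either aromatic ring, and in both cases the number falls, which on this read-out means stronger inhibition. Nothing at hand bears on why a single fluoro atom at this place moves the number, so the step stands as an observation without an explanation.

The compounds shown leave open whether this step is particular to fluoro or would also come with chloro, methoxy, a hydroxyl group or a carboxylic acid on the same carbon. They also leave open what happens when bromo on the sulfonyl-bearing ring and fluoro on the cinnamoyl side stand together in a single compound.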